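The compounds below may be only part of what the source reports. "The series", "measured", "known", "first", "only" and "open" are said of these compounds alone.

Measured so far in a physicochemical assay for solubility, read by HPLC, in phosphate buffer, at pH 6.5; on this read-out higher numbers stand for higher solubility and lower numbers for lower solubility:
- Compound 1 `COC(=O)C1=C(CN2CCC(F)(F)CC2)NC(c2nccs2)=NC1(C)c1ccc(F)cc1`: < 1 ug/mL (a limit)
- Compound 2 `COC(=O)C1=C(COCC(F)(F)F)NC(c2nccs2)=NC1(C)c1ccc(F)cc1`: 19 ug/mL

Within the data shown here, compound 2 stands at 19 ug/mL, the only value so far that is a number and not a limit. Compound 3 `COC(=O)C1=C(COC(C(=O)O)C(F)(F)F)NC(c2nccs2)=NC1(C)c1ccc(F)cc1` differs from compound 2 in one place: carboxy in place of hydrogen on a saturated chain carbon bound to an oxygen on a saturated carbon and a saturated chain carbon. The same difference reads 2,2,2-trifluoroethyl to 1-carboxy-2,2,2-trifluoroethyl.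

Among the measured compounds shown here, only one measured step bears on this, and only loosely, as it is a different exchange of groups: an at least 19-fold higher number from compound 1 to compound 2 (1.27 log units; beyond the scatter). Compound 1 stands at a limit: the limit of < 1 ug/mL in this assay, at which 1 of the 2 values shown sits. Taking that large step as the only guide to size, a large step to a higher number is expected in this assay, with wide uncertainty. The expected step is an 11-fold higher number from compound 2 to compound 3 (1.02 log units; beyond the scatter). For compound 3 the estimated value is 200 ug/mL, with an expected range of 40 ug/mL to 1000 ug/mL.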

Compound 3, solubility: > 649 ug/mL
Compound 3 ended at the assay's limit; the forecaster's own chance of this, stated with the estimate: 5%; at least 3.2-fold (0.51 log units) between middle value and limit.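

In this assay, carboxy in place of hydrogen on a saturated chain carbon bound to an oxygen on a saturated carbon and a saturated chain carbon gives an at least 34-fold higher number from compound 2 to compound 3 (1.53 log units; beyond the scatter). The earlier compounds shown here showed only an exchange of the whole group on the saturated chain carbon bound to a double-bonded ring carbon; here 2,2,2-trifluoroethyl becoming 1-carboxy-2,2,2-trifluoroethyl also gives a large step, and the exchange from the 4,4-difluoropiperidin-1-yl compound comes to an at least 640-fold higher number from compound 1 to compound 3 (2.81 log units; beyond the scatter). Compound 3 stands at a limit and not a number, so both steps fix only a minimum size: the limit of > 649 ug/mL in this assay, at which 1 of the 3 values shown sits.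

From the compounds shown here alone, what a methyl ester, a primary amide or an amine on the same carbon would read stays open, as does the actual number for compound 3. Any read-out other than this assay also remains open for this change.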